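A few compounds are considered here, and "the series" means these few. Any claim that something is new, unique, unknown or untested is made for them only; others in the source may bear on it.

Measured compounds:
- compound 1 `N/C(=N\NC(=S)N1CCOCC1)c1ccccn1`, 680 nM
- compound 2 `Cc1ccnc(/C(N)=N/NC(=S)N2CCOCC2)c1`, 1600 nM
- compound 3 `Cc1cccc(/C(N)=N/NC(=S)N2CCSCC2)n1`, 1400 nM

The read-out throughout is a functional assay on A-375 cells (Homo sapiens) for cytotoxicity, read by MTT assay, with a stated time of 72 h; on this read-out lower numbers stand for stronger inhibition and higher numbers for weaker inhibition. On the three numbers in hand compound 2 carries the highest value, with compound 3 close by and within the scatter of it, and compound 1 set apart: the one-place step a 2.4-fold higher number from compound 1 to compound 2 (0.37 log units; beyond the scatter) is the only step that can be computed among these three, since compound 3 differs from each of the others in two places at once.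

Compound 4 `Cc1ccnc(/C(N)=N/NC(=S)N2CCSCC2)c1` is the next entry. The change from compound 2 is thiomorpholin-4-yl in place of morpholin-4-yl on a thiocarbonyl carbon. Among the compounds with values here, no measured step isolates this exchange. Compound 3 already carries the thiomorpholin-4-yl group, but with methyl on a different aromatic carbon. In this assay compound 3 gives 1400 nM, while compound 2 gives 1600 nM, two values that sit within the scatter of each other. Within the data shown here, the one measured step, from compound 1 to compound 2, concerns the methyl and not the ring, so it does not bear on this exchange.

With nothing pointing either way, the step of a 1.1-fold lower number from compound 2 to compound 4 (0.03 log units; within the scatter) is expected to stay within the scatter. Compound 4 is therefore estimated at 1500 nM, with a range from 700 nM to 3200 nM.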

Compound 4, half-maximal inhibitory concentration: 1200 nM
The estimate for compound 4 lay 1.3-fold (0.10 log units) above the measured number; low and high end bracket the measured number.
By their numbers in this assay, from the lowest: compounds 1, 4, 3 and 2 (each within the scatter of the next, the first and the last beyond it).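

In this assay the exchange of morpholin-4-yl for thiomorpholin-4-yl on a thiocarbonyl carbon can now be read as a single change, and the step of a 1.3-fold lower number from compound 2 to compound 4 (0.12 log units; within the scatter) shows that, for this one pair, oxygen and sulfur in the ring cannot be told apart on this read-out. Within the data shown here, the only other step, a 2.4-fold higher number from compound 1 to compound 2 (0.37 log units; beyond the scatter) and so beyond the scatter, concerns methyl in place of hydrogen on an aromatic carbon, so the methyl change remains the only one-place change seen to shift the number, while this ring exchange does not. No measurement at hand bears on why the ring exchange leaves the number within the scatter.

From the compounds shown here alone, it remains open whether the same exchange would also stay within the scatter on the core of compound 1 , which gives 680 nM and carries no methyl. Also open, going by these compounds, is whether a piperazin-1-yl ring, with nitrogen in place of the ring oxygen or sulfur, or an open-chain dimethylamino group on the thiocarbonyl carbon would give a step beyond the scatter.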